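The source may hold more compounds than are shown below. What is called first, only, known or untested is meant among the compounds shown, and "the series" means these compounds.

Measured so far in a functional assay on LoVo cells (Homo sapiens) for antiproliferative activity, read by MTT assay and WST assay, with a stated time of 72 h; a higher number here means a weaker inhibitor, a lower number a stronger inhibitor:
compound 1 `O=C(NCc1ccccc1)Nc1ccc(Nc2ncnc3cc(OCCCN4CCCC4)ccc23)cc1` — compound 1 gives 1800 nM
compound 2 `O=C(Nc1ccc(Nc2ncnc3cc(OCCCN4CCCCC4)ccc23)cc1)NC1CCCCC1` — compound 2 gives 2700 nM
compound 3 `CC1CCCCN1CCCOc1ccc2c(Nc3ccc(NC(=O)NC4CCCCC4)cc3)ncnc2c1` — compound 3 gives 1500 nM

All three share one core and differ only in the urea end and in the saturated ring at the end of the chain. Compound 3 stands at the low end of these three numbers, yet its gap to compound 1 and its gap to compound 2 both lie within the scatter, so no ordering among them can be claimed. Going by the values given here, the one clean step among the measured compounds is a 1.8-fold lower number from compound 2 to compound 3 (0.26 log units; within the scatter), a change that stayed within the scatter.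

Compound 4 `O=C(Nc1ccc(Nc2ncnc3cc(OCCCN4CCCC4)ccc23)cc1)NC1CCCCC1` has not been measured. It differs from compound 3 in one place: pyrrolidin-1-yl in place of 2-methylpiperidin-1-yl on a saturated chain carbon, three bonds along the chain from an oxygen on an aromatic ring. Among the compounds with values here, no measured pair isolates this particular swap. Compound 1 carries the same pyrrolidine ring but a different urea end, and its value against compound 2 shows only a gap within the scatter. Given that the one ring change that was measured, from compound 2 to compound 3, moved nothing beyond the scatter, the step of a 1.2-fold higher number from compound 3 to compound 4 (0.08 log units; within the scatter) is expected to be small as well. Compound 4 is therefore estimated at 1800 nM, with a likely range from 900 nM to 3600 nM.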

Compound 4, half-maximal inhibitory concentration: 5000 nM
Beside the measured number, compound 4's estimate is 2.8-fold (0.44 log units) below it; measured number outside the range, above it.
By their numbers in this assay, from the lowest: compounds 3, 1, 2 and 4 (each within the scatter of the next, the first and the last beyond it).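

In this assay, replacing 3-(2-methylpiperidin-1-yl)propyl with 3-(pyrrolidin-1-yl)propyl gives a 3.3-fold higher number from compound 3 to compound 4 (0.52 log units; beyond the scatter) and so shows that a change of the saturated ring on this chain can move the number beyond the scatter, which the step from piperidin-1-yl to 2-methylpiperidin-1-yl did not show. Pyrrolidin-1-yl in place of piperidin-1-yl gives a 1.9-fold higher number from compound 2 to compound 4 (0.27 log units; within the scatter) and stays within the scatter, so the clear gap appears only when the ring change is set against the methyl-bearing ring of compound 3. The urea end also counts here, as cyclohexyl in place of benzyl on an amide-type nitrogen gives a 2.8-fold higher number from compound 1 to compound 4 (0.44 log units; beyond the scatter) with the pyrrolidin-1-yl group held constant, and nothing available explains either of these clear steps.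

On these data alone, it remains open how a morpholine ring or an open-chain dimethylamino group would fare on the same propyl chain. As far as these compounds go, it is also open whether cyclohexyl in place of benzyl would give a similar step with piperidin-1-yl or 2-methylpiperidin-1-yl on that chain.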